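The source may hold more compounds than are shown below. What is called first, only, known or untested is meant among the compounds shown, and "the series" means these compounds.

Measured compounds:
- compound 1, `C[C@@H]1CN(c2sc(C(F)(F)F)nc2-c2nc3ccccc3[nH]2)CCN1C(=O)CN1C(=O)OC[C@@H]1c1ccccc1`, 1380 nM
- compound 2, `Cc1nc(C)n(CC(=O)N2CCN(c3sc(C(F)(F)F)nc3-c3nc4c(C(F)(F)F)cccc4[nH]3)C[C@H]2C)n1`, 747 nM

In a functional assay on Venous blood for antagonist activity at C-X-C chemokine receptor type 3 (Homo sapiens), read by flow cytometry, with a stated time of 30 min, in the presence of a further agent that is not named here (a lower number here means a stronger inhibitor, a higher number a weaker inhibitor), compound 1 gives 1380 nM, the higher of the two numbers recorded; compound 2 gives 747 nM, and the gap between the two values lies within the usual scatter, so nothing separates them in this assay. For the measured compounds named here, compound 2 also differs from compound 1 in more than one place, so no single step between measured compounds can be read from this pair.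

Compound 3, `C[C@@H]1CN(c2sc(C(F)(F)F)nc2-c2nc3ccccc3[nH]2)CCN1C(=O)Cn1cc(C2CCN(C)CC2)cn1`, is not yet measured. It differs from compound 1 in one place: 4-(1-methylpiperidin-4-yl)-1H-pyrazol-1-yl in place of 2-oxo-4-phenyl-1,3-oxazolidin-3-yl on a saturated chain carbon bound to a carbonyl carbon. The new group keeps the same count of heavy atoms as the one it replaces, with an aromatic five-membered ring carrying the six-membered non-aromatic ring in place of the non-aromatic ring carrying a phenyl. Going by the values given here, with no measured step for this kind of exchange, the expected change from compound 1 to compound 3 is small, a 1.6-fold lower number from compound 1 to compound 3 (0.21 log units; within the scatter), and may not exceed the scatter. Compound 3 is therefore estimated at 850 nM, with a range from 250 nM to 3000 nM.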

Compound 3, half-maximal inhibitory concentration: 1690 nM
The estimate for compound 3 lay 2.0-fold (0.30 log units) below the measured number; low and high end bracket the measured number.
By their numbers in this assay, from the lowest: compounds 2, 1 and 3 (each within the scatter of the next, the first and the last beyond it).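

For the compounds shown here, the step gives the first reading at this position, on a saturated chain carbon bound to a carbonyl carbon. The earlier pair differed in more than one place. In this assay, putting 4-(1-methylpiperidin-4-yl)-1H-pyrazol-1-yl in place of 2-oxo-4-phenyl-1,3-oxazolidin-3-yl gives a 1.2-fold higher number from compound 1 to compound 3 (0.09 log units; within the scatter), so this assay does not separate the two groups, although the entering group has an aromatic five-membered ring carrying a six-membered non-aromatic ring, three nitrogens and no defined stereocentre, while the leaving group has a non-aromatic ring carrying a phenyl, two oxygens and one defined stereocentre. Nothing measured here bears on why two such different groups read alike.

The compounds shown leave open whether the same holds for groups of another kind at this position, such as a carboxylic acid, a primary amine or a single methyl, or for a longer chain between the carbonyl and the ring. Going by these compounds alone, they also leave open what the additional trifluoromethyl group in compound 2 contributes on its own, since no single step isolates it.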